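Replacing bromo with methyl in a small inhibitor series

This account rests on a few compounds, and the source may have more. Where it says the series, first, only, none or still open, it means among the compounds named here.

Measured so far in a functional assay on HepG2 cells (Homo sapiens) for inhibition, read by MTT assay, with a stated time of 24 h; a lower number here means a stronger inhibitor, a higher number a weaker inhibitor:
- compound 1 `CC1(C)[C@H]2CC[C@]1(C)N(Cc1cn(-c3ccc(C#N)cc3)nn1)C(=O)C2` gives 50 nM
- compound 2 `Cc1ccccc1-n1cc(CN2C(=O)C[C@@H]3CC[C@@]2(C)C3(C)C)nn1` gives 150 nM
- compound 3 `CC1(C)[C@H]2CC[C@]1(C)N(Cc1cn(-c3cccc(Br)c3)nn1)C(=O)C2` gives 20 nM

Compound 3 gives the lowest number of the three, and its value of 20 nM stands clear of the other two. The data show a 2.5-fold lower number from compound 1 to compound 3 (0.40 log units; beyond the scatter) and also a 7.5-fold lower number from compound 2 to compound 3 (0.88 log units; beyond the scatter) on the way down to it.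

Compound 4 `Cc1cccc(-n2cc(CN3C(=O)C[C@@H]4CC[C@@]3(C)C4(C)C)nn2)c1` departs from compound 3 in one place, methyl in place of bromo on an aromatic carbon, meta to a large group, a difference that counts as methyl in place of bromo on an aromatic carbon with the shared core untouched.

Among the measured compounds shown here, no measured step makes this exact exchange. The closest guide is a 7.5-fold lower number from compound 2 to compound 3 (0.88 log units; beyond the scatter) but it alters the group and its place together, so it serves only as an outer bound. Alongside it, a 3.0-fold higher number from compound 1 to compound 2 (0.48 log units; beyond the scatter) shows that the aryl group matters in this assay across the series. For the measured compounds named here, compound 2, the only measured compound with a methyl, gives 150 nM as its value, so a modest move to a higher number is expected here, smaller than the closest guide.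

The step expected is a 3.0-fold higher number from compound 3 to compound 4 (0.48 log units; beyond the scatter) in this estimate.

Compound 4 is expected near 60 nM in this assay with 20 nM to 180 nM as the estimated range.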

Compound 4, half-maximal inhibitory concentration: 300 nM
Beside the measured number, compound 4's estimate is 5.0-fold (0.70 log units) below it; measured number outside the range, above it.
By their numbers in this assay, from the lowest: compound 3; then compound 1; then compounds 2 and 4 (each within the scatter of the next).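

In this assay, the exchange of bromo for methyl on the aromatic carbon, meta to a large group, gives the largest step in this set, with a 15-fold higher number from compound 3 to compound 4 (1.18 log units; beyond the scatter) marking a sharp loss of inhibition from one heavy atom changed. Methyl placement offers no such separation: a 2.0-fold higher number from compound 2 to compound 4 (0.30 log units; within the scatter) leaves the 2-methylphenyl and 3-methylphenyl compounds indistinguishable, so the low number of compound 3 goes with the 3-bromophenyl group and is not reproduced by a methyl at the same place. Among the compounds shown here, the 4-cyanophenyl group also keeps its compound ahead of this new methyl compound, as a 6.0-fold higher number from compound 1 to compound 4 (0.78 log units; beyond the scatter) shows, which leaves compound 3 as the only compound here with a lower number than compound 1.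

Nothing available here explains why this exchange changes the number so strongly. Still open, from the compounds shown here alone, is whether the result is specific to bromo, which chloro, methoxy or trifluoromethyl on the same carbon would test, and whether bromo keeps its advantage as 2-bromophenyl or 4-bromophenyl.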